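Swapping One Aryl Amide on a Cyclohexane Diamide Core

A few compounds are considered here, and "the series" means these few. Any claim that something is new, unique, unknown or untested is made for them only; others in the source may bear on it.

Compound 1, `O=C(N[C@H]1CCC[C@H](NC(=O)c2cnccn2)C1)c1cccc(Cl)c1`, gives 1370 nM in a functional assay on HEK293 cells for antagonist activity at metabotropic glutamate receptor 5 (Homo sapiens), read by FLIPR and calcium flux; on this read-out lower numbers stand for stronger inhibition and higher numbers for weaker inhibition.
Compound 2, `Cc1cccnc1C(=O)N[C@H]1CCC[C@H](NC(=O)c2cccc(Cl)c2)C1`, gives 7840 nM in this assay.

Both compounds share a core with two amide arms, and only the group on one carbonyl carbon changes. Compound 2 holds the highest of the two numbers; its nearest neighbour is compound 1, with a 5.7-fold higher number from compound 1 to compound 2 (0.76 log units; beyond the scatter). That single step is the only one that bears on the next change.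

Compound 3, `O=C(N[C@H]1CCC[C@H](NC(=O)c2cccc(Cl)c2)C1)c1ccc(F)cc1`, is not yet measured. It differs from compound 2 in this way: 4-fluorophenyl in place of 3-methylpyridin-2-yl on a carbonyl carbon. Going by the values given here, the one measured step at this same position shows that exchanging the aromatic group here can move the number by a modest but real amount. The direction for a carbon-only ring carrying a fluorine is not told by the data; a number anywhere from near compound 1 to near compound 2 seems plausible, and an estimate is placed between them. Compound 3 is therefore expected to give about 3000 nM in this assay, with a range from 800 nM to 12000 nM, which means an expected 2.6-fold lower number from compound 2 to compound 3 (0.42 log units; beyond the scatter).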

Compound 3, half-maximal inhibitory concentration: 194 nM
For compound 3 the middle estimate is 15-fold (1.19 log units) above the measured one; measured number outside the range, below it.
By their numbers in this assay, from the lowest: compound 3; then compound 1; then compound 2.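

Putting 4-fluorophenyl on the carbonyl carbon in this assay gives a 40-fold lower number from compound 2 to compound 3 (1.61 log units; beyond the scatter), and the same group gives a 7.1-fold lower number from compound 1 to compound 3 (0.85 log units; beyond the scatter). The first of these steps is large and the second modest, so this position can move the number much further than the earlier exchange between two nitrogen-containing rings revealed, and the change can run towards stronger inhibition as well as weaker. Among these three compounds, the ring of carbon only gives the lowest number, and both rings with a nitrogen atom give higher ones, with no compound here going against that order, yet no measurement shown here explains the gain.

The compounds shown leave open how much of this step belongs to the fluorine and how much to the ring of carbon only, a question that a plain phenyl group on the same carbonyl carbon would help to separate. Also open, on these data alone, is how a phenyl ring carrying an amine or a carboxylic acid in place of the fluorine would read in this assay.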